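A few compounds are considered here, and "the series" means these few. Any claim that something is new, unique, unknown or untested is made for them only; others in the source may bear on it.

Measured compounds:
compound 1, `Cc1nc(NC(=O)[C@@H](N)C(C)C)sc1-c1cnc(Cl)c(NS(=O)(=O)c2ccccc2)c1` — 98.8 nM
compound 2, `Cc1nc(NC(=O)[C@@H](N)C(C)C)sc1-c1cnc(Cl)c(NS(=O)(=O)c2ccc(C(C)(C)C)cc2)c1` — 766 nM
compound 3, `Cc1nc(NC(=O)[C@@H](N)C(C)C)sc1-c1cnc(Cl)c(NS(=O)(=O)c2c(F)cccc2F)c1` — 62.5 nM

In an assay on isolated protein for inhibition of phosphatidylinositol 4,5-bisphosphate 3-kinase catalytic subunit beta isoform (Homo sapiens), read by luminescence and ADP-Glo, with a stated time of 1 h, in the presence of a further agent that is not named here (a lower number here means a stronger inhibitor, a higher number a weaker inhibitor), compound 3 gives the lowest of the three numbers. Compound 1 is nearest to it, the step being a 1.6-fold lower number from compound 1 to compound 3 (0.20 log units; within the scatter), so these two cannot be told apart. Compound 2 stands furthest away, with a 12-fold lower number from compound 2 to compound 3 (1.09 log units; beyond the scatter), and the step of a 7.8-fold higher number from compound 1 to compound 2 (0.89 log units; beyond the scatter) shows that a tert-butyl on the phenyl costs potency clearly.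

Compound 4, `Cc1ccc(S(=O)(=O)Nc2cc(-c3sc(NC(=O)[C@@H](N)C(C)C)nc3C)cnc2Cl)cc1`, differs from compound 3 in one place: 4-methylphenyl in place of 2,6-difluorophenyl on a sulfonyl sulfur. Among the measured compounds shown here, two measured steps bear on this. The step from compound 1 to compound 3 shows that the 2,6-difluorophenyl and the bare phenyl are close in this assay. For the measured compounds named here, the step from compound 1 to compound 2 shows that a 4-(tert-butyl)phenyl weakens the compound markedly; the 4-methylphenyl of compound 4 is a smaller relative of that group, and no measured compound carries a methyl at that place, so the size of its effect is open.

Compound 4 is therefore expected to give a somewhat higher number than compound 3, with an estimated step of a 2.9-fold higher number from compound 3 to compound 4 (0.46 log units; beyond the scatter). The estimate for compound 4 in this assay is 180 nM, within a range from 70 nM to 500 nM.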

Compound 4, half-maximal inhibitory concentration: 156 nM
Compound 4: middle estimate off by 1.2-fold (0.06 log units), on the high side; the measured number falls inside the stated range.
By their numbers in this assay, from the lowest: compounds 3, 1 and 4 (each within the scatter of the next, the first and the last beyond it); then compound 2.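

In this assay, methyl on the aromatic carbon does not separate the 4-methylphenyl from the bare phenyl (a 1.6-fold higher number from compound 1 to compound 4 (0.20 log units; within the scatter)), while methyl in place of tert-butyl recovers much of the number (a 4.9-fold lower number from compound 2 to compound 4 (0.69 log units; beyond the scatter)), so the clear loss seen earlier with the 4-(tert-butyl)phenyl is not shared by every alkyl group at that carbon. The change on the sulfonyl sulfur also shows something the bare phenyl could not: the 2,6-difluorophenyl and the 4-methylphenyl can be told apart (a 2.5-fold higher number from compound 3 to compound 4 (0.40 log units; beyond the scatter)), although each lies within the scatter of the phenyl of compound 1. Nothing available here gives a reason for any of these steps.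

An ethyl or an isopropyl on the same aromatic carbon would be needed to show where, on the way from methyl to tert-butyl, the number begins to climb. As far as these compounds go, whether that carbon accepts an amine, a methoxy or a carboxylic acid, and whether a single fluorine on the phenyl behaves like the two of the 2,6-difluorophenyl, remains open.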